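The compounds below may be only part of what the source reports. "The series", "measured", "known", "first", "only" and "open" are said of these compounds alone.

Three compounds have been measured in a functional assay on MCF7 cells (Homo sapiens) for antiproliferative activity, read by MTT assay, with a stated time of 48 h; on this read-out lower numbers stand for stronger inhibition and higher numbers for weaker inhibition:

compound 1, `Fc1ccc(-c2nn(-c3ccccc3)cc2-c2nc3cc(Cl)ccc3[nH]2)cc1`, gives 2230 nM
compound 2, `Fc1ccc(-c2nn(-c3ccccc3)cc2-c2nc3cc(Br)ccc3[nH]2)cc1`, gives 3210 nM
compound 3, `COc1ccc(-c2nn(-c3ccccc3)cc2-c2nc3cc(Cl)ccc3[nH]2)cc1`, gives 1760 nM

The three share one core and differ at two places. Compound 1 and compound 2 differ by bromo in place of chloro on an aromatic carbon, and this gave a 1.4-fold higher number from compound 1 to compound 2 (0.16 log units; within the scatter). Compound 1 and compound 3 differ by methoxy in place of fluoro on an aromatic carbon, and this gave a 1.3-fold lower number from compound 1 to compound 3 (0.10 log units; within the scatter). Neither step is larger than what repeated measurements of this kind usually show, so nothing can be said about which of the three numbers is the stronger.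

Compound 4, `COc1ccc(-c2nn(-c3ccccc3)cc2-c2nc3cc(Br)ccc3[nH]2)cc1`, is not yet measured. It differs from compound 3 by bromo in place of chloro on an aromatic carbon. This is the same change that was made from compound 1 to compound 2, at the same place on the same ring, and it occurs twice among the four compounds. What separates the two pairs is the difference between compound 1 and compound 3, given by methoxy in place of fluoro on an aromatic carbon.

The expectation for compound 4 therefore rests on a single earlier case. Because a 1.4-fold higher number from compound 1 to compound 2 (0.16 log units; within the scatter) was small, the step expected in this assay is also small, namely a 1.4-fold higher number from compound 3 to compound 4 (0.13 log units; within the scatter). Compound 4 is accordingly expected to give about 2400 nM, with a likely range from 1200 nM to 4800 nM, the width reflecting that one prior example is a thin basis.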

Compound 4, half-maximal inhibitory concentration: 1830 nM
Compound 4: middle estimate off by 1.3-fold (0.12 log units), on the high side; low and high end bracket the measured number.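

In this assay, bromo in place of chloro on the methoxy-bearing core gave a 1.0-fold higher number from compound 3 to compound 4 (0.02 log units; within the scatter), and set beside the earlier case on the fluoro-bearing core, the two steps agree: the same change on two cores in this assay, a 1.4-fold higher number (0.16 log units; within the scatter) from compound 1 to compound 2 and a 1.0-fold higher number (0.02 log units; within the scatter) from compound 3 to compound 4, 1.4-fold (0.14 log units) apart, within the scatter of two such steps. Methoxy in place of fluoro, now read on the bromo-bearing core, gave a 1.8-fold lower number from compound 2 to compound 4 (0.24 log units; within the scatter), and this step also agrees with its earlier case: the same change on two cores in this assay, a 1.3-fold lower number (0.10 log units; within the scatter) from compound 1 to compound 3 and a 1.8-fold lower number (0.24 log units; within the scatter) from compound 2 to compound 4, 1.4-fold (0.14 log units) apart, within the scatter of two such steps. Among these compounds, each change therefore carried from one core to the other without a discernible difference, but as all four steps lie within the scatter, this shows only that neither change moved the number measurably on these two cores, and it does not show that a small real effect of either change is present, absent or the same on both.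

The compounds shown leave open what an amine or a carboxylic acid would do on the aromatic carbon that holds the chloro or bromo, and what a longer chain would do in place of the methoxy. They also leave open whether a change that gives a step beyond the scatter would carry from one core to another in the same way.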